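The source may hold more compounds than are shown below. What is called first, only, known or untested is meant among the compounds shown, and "the series" means these compounds.

Measured so far:
compound 1, `O=C(/C=C/c1ccc(OCCCCO[N+](=O)[O-])c(O)c1)OCCCCO[N+](=O)[O-]`, in a functional assay on A549 cells (Homo sapiens) for cytotoxicity, read by resazurin assay, with a stated time of 72 h (on this read-out lower numbers stand for stronger inhibition and higher numbers for weaker inhibition), gives 410 nM
compound 2, `O=C(/C=C/c1ccc(O)c(O)c1)OCc1c(-c2ccccc2)no[n+]1[O-]`, gives 2710 nM
compound 3, `COc1cc(/C=C/C(=O)OCc2c(-c3ccccc3)no[n+]2[O-])ccc1O`, gives 2060 nM

Compound 1 stands lowest of the three numbers, and both compound 3 and compound 2 lie beyond the scatter above it. The difference between the core of compound 1 and the core of compound 2 is not broken down here. Within the second pair, compound 3 differs from compound 2 by methyl in place of hydrogen on an oxygen on an aromatic ring and that step read a 1.3-fold lower number from compound 2 to compound 3 (0.12 log units; within the scatter). Compound 4, `COc1cc(/C=C/C(=O)OCCCCO[N+](=O)[O-])ccc1OCCCCO[N+](=O)[O-]`, carries the same change on the core of compound 1: methyl in place of hydrogen on an oxygen on an aromatic ring. Because the earlier step was a 1.3-fold lower number from compound 2 to compound 3 (0.12 log units; within the scatter), compound 4 is expected to stay close to compound 1 in this assay. The expected step is a 1.1-fold lower number from compound 1 to compound 4 (0.03 log units; within the scatter). Compound 4 is estimated at 380 nM, between 150 nM and 950 nM.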

Compound 4, half-maximal inhibitory concentration: > 50000 nM
Compound 4 was reported as a limit; the forecaster's own chance of this, stated with the estimate: 3%; middle value at least 130-fold (2.11 log units) away from the limit.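

In this assay compound 4 gives > 50000 nM, which is a limit of the assay and not a number. On the core of compound 1, hydroxy to methoxy reads an at least 120-fold higher number from compound 1 to compound 4 (2.08 log units; beyond the scatter), so the change did not carry over from the other core, where its step stayed within the scatter: the same change on two cores in this assay, a 1.3-fold lower number (0.12 log units; within the scatter) from compound 2 to compound 3 and an at least 120-fold higher number (2.08 log units; beyond the scatter) from compound 1 to compound 4, at least 160-fold (2.20 log units) apart, beyond the scatter of two such steps This rests on a single pair on each core, and it does not show why the two cores part or what the change would do on any further core.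

The compounds shown leave open whether an ethyl group or a longer chain on that oxygen would read as methyl does on the core of compound 1. They also leave open how a carboxylic acid in place of the ester would read on either core.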